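The compounds below may be only part of what the source reports. "The series", "measured", "known", "first", "only" and "open" are said of these compounds alone.

Measured compounds in a functional assay (aorta) with Rattus norvegicus as the target; on this read-out lower numbers stand for stronger inhibition and higher numbers for weaker inhibition:
- compound 1 `CC1(C)Oc2ccc(C#N)cc2[C@@H](/N=C(\NC#N)Nc2ccc(N)cc2)[C@@H]1O`: 3500 nM
- compound 2 `CC1(C)Oc2ccc(C#N)cc2[C@@H](NC(=O)Nc2cccnc2)[C@@H]1O`: 500 nM

Of the two numbers, compound 1 gives the higher one. Compound 2, which carries a different linker and aryl group on the same core, gives the lower number, and the gap between the two is beyond the usual scatter, so compound 1 is the weaker of the pair on this assay.

The next compound, compound 3 `Cc1ccc(N/C(=N/[C@@H]2c3cc(C#N)ccc3OC(C)(C)[C@H]2O)NC#N)cc1C`, keeps the cyanoguanidine linker of compound 1 and changes only the aryl group on the amine nitrogen: 3,4-dimethylphenyl in place of 4-aminophenyl on an amine nitrogen. Among the compounds with values here, no measured pair shows a step of this kind, so there is nothing to lean on beyond the two values above. The expectation is a modest lowering of the number from compound 1, at the edge of the scatter rather than clearly beyond it, as the step of a 1.8-fold lower number from compound 1 to compound 3 (0.24 log units; within the scatter) is estimated. The estimate for compound 3 in this assay is 2000 nM, with a range from 500 nM to 8000 nM.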

Compound 3, half-maximal inhibitory concentration: 5100 nM
Beside the measured number, compound 3's estimate is 2.6-fold (0.41 log units) below it; the range from low to high includes it.
By their numbers in this assay, from the lowest: compound 2; then compounds 1 and 3 (each within the scatter of the next).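

On the cyanoguanidine linker, the amine nitrogen whose other neighbour is the carbon with a double bond to nitrogen takes 3,4-dimethylphenyl in place of 4-aminophenyl with a 1.5-fold higher number from compound 1 to compound 3 (0.16 log units; within the scatter) in this assay, so this exchange of aryl groups is not resolved from the scatter. The 4-aminophenyl group counts one hydrogen-bond donor and one hydrogen-bond acceptor and 3,4-dimethylphenyl counts neither, yet the two groups are not separated on this read-out. No supporting measurement bears on this result.

On these data alone, compound 2 differs from compound 1 in both linker and aryl group, so that pair cannot be read as a step, and it remains open whether the linker, the aryl group or both account for the value of compound 2, 500 nM. Also open, as far as these compounds go, is whether a carboxylic acid or a longer chain on the phenyl ring, in place of the amine of compound 1, would move the number beyond the scatter on the cyanoguanidine linker.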